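Swapping the bicyclic amide head: from compound 3 to compound 4

The compounds below may be only part of what the source reports. "The series", "measured", "known", "first", "only" and "open" are said of these compounds alone.

Compound 3 `O=C(NCc1ccc(S(=O)(=O)c2ccccc2)cc1)c1cn2ccnc2cn1` gives 150 nM in an assay for inhibition of Nicotinamide phosphoribosyltransferase (Homo sapiens), read by mass spectrometry, with stated times of 15 min and 30 min (on this read-out lower numbers stand for stronger inhibition and higher numbers for weaker inhibition), the second highest of the three numbers; compound 1 `O=C(NCc1ccc(S(=O)(=O)c2ccccc2)cc1)c1cc2ncccc2s1` gives 400 nM and compound 2 `O=C(NCc1ccc(S(=O)(=O)c2ccccc2)cc1)c1ccc2nccn2c1` gives 18 nM. Compound 4 `O=C(NCc1ccc(S(=O)(=O)c2ccccc2)cc1)c1c[nH]c2ccncc12` differs from compound 3 by a group of 9 heavy atoms (7 carbon, 2 nitrogen; one five-membered aromatic ring with 1 hetero atom, one six-membered aromatic ring with 1 hetero atom) in place of a group of 9 heavy atoms (6 carbon, 3 nitrogen; one five-membered aromatic ring with 2 hetero atoms, one six-membered aromatic ring with 2 hetero atoms), on a carbonyl carbon. The step that bears most on this change is a 2.7-fold lower number from compound 1 to compound 3 (0.43 log units; beyond the scatter), since the group entering in compound 4 resembles that of compound 1 in ring hetero atom count, while an 8.3-fold higher number from compound 2 to compound 3 (0.92 log units; beyond the scatter) shows that a group with fewer ring nitrogens can also give a much lower number. The expected step is therefore no change at the digits printed from compound 3 to compound 4 (within the scatter), with wide uncertainty. Compound 4 is expected to give about 150 nM, in a range from 35 nM to 600 nM.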

Compound 4, half-maximal inhibitory concentration: 1900 nM
Beside the measured number, compound 4's estimate is 13-fold (1.10 log units) below it; measured number outside the range, above it.
By their numbers in this assay, from the lowest: compound 2; then compound 3; then compound 1; then compound 4.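

Among these four compounds, compound 4 is the weakest, with a 13-fold higher number from compound 3 to compound 4 (1.10 log units; beyond the scatter), a 4.8-fold higher number from compound 1 to compound 4 (0.68 log units; beyond the scatter) and a 110-fold higher number from compound 2 to compound 4 (2.02 log units; beyond the scatter). The last step is the largest, although both groups hold 7 carbon and 2 nitrogen atoms, so on a carbonyl carbon the same atom count does not ensure a similar number. The data shown give no reason for this result.

From the compounds shown here alone, it remains open whether the hydrogen on the nitrogen of the five-membered ring matters. A methyl group in its place would test this.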